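Moving the Fluorine Along a Benzylsulfonamide Side Chain

The compounds below may be only part of what the source reports. "The series", "measured", "known", "first", "only" and "open" are said of these compounds alone.

Compound 2 `N#Cc1cc2c(nc1N1CCC(C(=O)NS(=O)(=O)Cc3ccccc3F)CC1)COC2=O` was tested in a functional assay (Platelet, plasma) for inhibition, with Homo sapiens as the target (a lower number here means a stronger inhibitor, a higher number a weaker inhibitor), where compound 2 gives 23700 nM. Of the two numbers shown, this is the lowest. Compound 1 `N#Cc1cc2c(nc1N1CCC(F)(C(=O)NS(=O)(=O)c3ccc(Cl)s3)CC1)COC2=O` in this assay gives 37100 nM, which lies within the scatter of the value of compound 2, so no order between the two can be drawn. Compound 3 `N#Cc1cc2c(nc1N1CCC(C(=O)NS(=O)(=O)Cc3ccccc3)CC1)CCC(Cl)C2=O` returned only a limit in this assay, > 300000 nM, and not a number; the picture is summed up by the limit of > 300000 nM in this assay, at which 1 of the 3 values shown sits.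

Compound 4 `N#Cc1cc2c(nc1N1CCC(C(=O)NS(=O)(=O)Cc3cccc(F)c3)CC1)COC2=O` has not yet been measured. It differs from compound 2 in one place: 3-fluorophenyl in place of 2-fluorophenyl on a saturated chain carbon bound to a sulfonyl sulfur. Within the data shown here, no measured pair shows this change, so its effect cannot be read from the numbers in hand. The step is expected to stay within the usual scatter, with a 1.1-fold higher number from compound 2 to compound 4 (0.02 log units; within the scatter) in this assay as the estimate. Compound 4 is thus expected to give about 25000 nM in this assay, with the estimate ranging from 8000 nM to 80000 nM.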

Compound 4, half-maximal inhibitory concentration: 70500 nM
Compound 4: the middle estimate sits 2.8-fold (0.45 log units) below what was measured; low and high end bracket the measured number.
By their numbers in this assay, from the lowest: compounds 2, 1 and 4 (each within the scatter of the next, the first and the last beyond it). At a limit, above all of these: compound 3.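

Among these compounds, the change from 2-fluorobenzyl to 3-fluorobenzyl gives a 3.0-fold higher number from compound 2 to compound 4 (0.47 log units; beyond the scatter) in this assay and is the first step in this set that can be read as a single change. The two compounds hold the same atoms, joined differently, so the place of the fluorine on the phenyl ring alone separates them, and the 2-fluorophenyl on a saturated chain carbon bound to a sulfonyl sulfur reads as the stronger of this one pair, though only modestly. Nothing measured here accounts for this step.

The compounds shown leave open how 4-fluorobenzyl or unsubstituted benzyl would read on the core of compound 2, so no trend along the ring can be claimed from one pair. Also open, from the compounds shown here alone, is how a carboxylic acid would compare in place of the sulfonamide.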